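The compounds below may be only part of what the source reports. "The series", "measured", "known", "first", "only" and "open" are said of these compounds alone.

The measured compounds in a functional assay on HeLa cells (Homo sapiens) for cytotoxicity, read by MTT assay, with a stated time of 48 h; on this read-out lower numbers stand for stronger inhibition and higher numbers for weaker inhibition:
Compound 1, `CCN(CC)c1ccc2cc(C(=O)c3ccc(N4CCN(C(=O)CN5CCN(S(=O)(=O)c6ccc(C#N)cc6)CC5)CC4)cc3)oc2c1`, gives 8470 nM.
Compound 2, `CCN(CC)c1ccc2cc(C(=O)c3ccc(N4CCN(C(=O)CN5CCN(Cc6ccc(C(F)(F)F)cc6)CC5)CC4)cc3)oc2c1`, gives only a limit of the assay, > 40000 nM.

Compound 2 thus stands at the weaker end of the pair. Its value in this assay is a limit and not a number, so its true position is known only as lying beyond that point. Compound 3, `CCOC(=O)CN1CCN(CC(=O)N2CCN(c3ccc(C(=O)c4cc5ccc(N(CC)CC)cc5o4)cc3)CC2)CC1`, differs from compound 2 in one place: ethoxycarbonyl in place of 4-(trifluoromethyl)phenyl on a saturated chain carbon bound to an amine nitrogen in a ring. For the measured compounds named here, only one measured step exists, an at least 4.7-fold higher number from compound 1 to compound 2 (0.67 log units; beyond the scatter), and it concerns a different exchange on the same amine nitrogen in a ring, so it does not test the change to ethoxycarbonyl directly. It shows only that this part of the molecule can move the number beyond the scatter. Going by the values given here, compound 2 sits at the limit of > 40000 nM in this assay, at which 1 of the 2 values shown sits, so no size for the step to compound 3 can be read from the data. The expected step of a number no higher from compound 2 to compound 3 (the limit leaves the size open) is therefore set near no change, with a wide range in both directions. Compound 3 is estimated at 40000 nM, with a range from 8000 nM to 120000 nM. There is a real chance that this assay again reports only a limit for compound 3.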

Compound 3, half-maximal inhibitory concentration: 22100 nM
Estimate against measurement, compound 3: 1.8-fold (0.26 log units) above; low and high end bracket the measured number.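

In this assay, going by these compounds, ethoxycarbonyl in place of 4-(trifluoromethyl)phenyl gives an at least 1.8-fold lower number from compound 2 to compound 3 (0.25 log units; that floor lies within the scatter), so this exchange on a saturated chain carbon yields a measured number, but the true size of the step remains unknown. Compound 2 holds a limit of the assay and not a number, which is why only a floor can be stated for that step: the limit of > 40000 nM in this assay, at which 1 of the 3 values shown sits.

The comparison with the sulfonyl compound is firmer and reads a 2.6-fold higher number from compound 1 to compound 3 (0.42 log units; beyond the scatter), for (ethoxycarbonyl)methyl in place of (4-cyanophenyl)sulfonyl on the same amine nitrogen in a ring; with both of its steps printed as beyond the scatter, compound 1 gives the lowest number of the three.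

The compounds shown leave open whether ethoxycarbonyl itself matters or whether simply losing the 4-(trifluoromethyl)phenyl ring is enough, which a carboxylic acid, a primary amide or a plain ethyl group at this place could help to separate. They also leave open whether the lower number of compound 1 belongs to the sulfonyl link or to its 4-cyanophenyl group, a question that a 4-cyanobenzyl group on the same nitrogen would address.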